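Furan-2-yl gives way to thiophen-2-yl at the assay limit

A few compounds are considered here, and "the series" means these few. Any claim that something is new, unique, unknown or untested is made for them only; others in the source may bear on it.

Of the compounds shown here, two have so far been tested in a functional assay on CEM-DNR-bulk cells (Homo sapiens), read by MTT assay, with a stated time of 72 h (a lower number here means a stronger inhibitor, a higher number a weaker inhibitor), and neither gave an exact number. Compound 1 `CN(C)c1ncnc2c1c(-c1ccsc1)cn2[C@@H]1O[C@H](CO)[C@@H](O)[C@H]1O` reads > 20000 nM as its result, which is a limit of the assay and not a number. Compound 2 `Nc1nc(N)c2c(-c3ccco3)cn([C@@H]3O[C@H](CO)[C@@H](O)[C@H]3O)c2n1` reads > 20000 nM as its result, again a limit. The picture so far is the limit of > 20000 nM in this assay, at which 2 of the 2 values shown sit, and so compound 2 has no exact place, and the two compounds cannot be put in order.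

Compound 3 `Nc1nc(N)c2c(-c3cccs3)cn([C@@H]3O[C@H](CO)[C@@H](O)[C@H]3O)c2n1` has not yet been measured. It differs from compound 2 in one place, on an aromatic carbon of a five-membered aromatic ring with 1 nitrogen, where thiophen-2-yl stands in place of furan-2-yl thiophen-2-yl in place of furan-2-yl on an aromatic carbon with sulfur taking the place of oxygen. With compound 2 at > 20000 nM as the closest guide, no step beyond the usual scatter is expected in this assay and neither direction is favoured. The expected move is a number no higher from compound 2 to compound 3 (the limit leaves the size open) and another limit is the likeliest outcome. For compound 3 the estimate is 20000 nM with an expected range from 7000 nM to 40000 nM if a number is obtained.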

Compound 3, half-maximal inhibitory concentration: > 20000 nM
Compound 3: only a limit was reported (the forecaster's own chance of this, stated with the estimate: 75%); the middle value lies on the limit itself.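

Compound 2 and compound 3 both end at a limit of the assay and not a number, so no step can be read for thiophen-2-yl in place of furan-2-yl: the limit of > 20000 nM in this assay, at which 3 of the 3 values shown sit.

The compounds shown leave open how furan-2-yl and thiophen-2-yl would compare in this assay, and whether any change to these compounds would give an exact number there.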